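Swapping one aryl group on a shared urea-pyrimidine core

The source may hold more compounds than are shown below. What is called first, only, known or untested is meant among the compounds shown, and "the series" means these compounds.

Measured so far:
- compound 1, `Cc1ccc(Nc2cc(NC(=O)Nc3c(Cl)cccc3Cl)ncn2)cc1C`: 84.3%
- compound 2, `COc1cc(NC(=O)Nc2cc(Nc3ccc(C)c(C)c3)ncn2)cc(OC)c1`: 45.7%
- compound 3, `CC(C)(C)c1ccc(Nc2cc(NC(=O)Nc3c(Cl)cccc3Cl)ncn2)cc1`: 42.3%

All three share the same core and were tested in a functional assay on HCC827 cells (Homo sapiens) for inhibition, read by MTT assay, with a stated time of 48 h, tested at 10 uM; a higher number here means more inhibition at the concentration tested (going by the name of the read-out), a lower number less inhibition. Compound 1 gives 84.3%, the highest of the three numbers. Compound 2 gives 45.7%, the second highest; its nearest neighbour is compound 3 at 42.3%, a gap within the usual scatter, so no order between compound 2 and compound 3 can be claimed. Its furthest neighbour is compound 1, a gap beyond the scatter.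

Compound 4, `COc1cc(NC(=O)Nc2cc(Nc3cc(C)cc(F)c3)ncn2)cc(OC)c1`, has not yet been measured. It differs from compound 2 in one place:

3-fluoro-5-methylphenyl in place of 3,4-dimethylphenyl on a nitrogen on an aromatic ring

Going by the values given here, no pair of measured compounds differs in only this way, so there is no measured step to lean on. The change keeps the size of the group and adds no donor or acceptor. The step from compound 2 to compound 4 in this assay is therefore expected to be small, a number 3.7 percentage points lower from compound 2 to compound 4 (within the scatter), not beyond the scatter. Compound 4 is estimated at 42%, likely between 22% and 62%.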

Compound 4, a percentage reported as inhibition, at one concentration (the size of the read-out at that concentration, not a potency): 62.1%
Compound 4: middle estimate off by 20.1 percentage points, on the low side, outside the stated range (above it).
By their numbers in this assay, from the lowest: compounds 3 and 2 (each within the scatter of the next); then compound 4; then compound 1.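

The aryl group on this nitrogen clearly matters: in this assay, 3-fluoro-5-methylphenyl in place of 3,4-dimethylphenyl gives a number 16.4 percentage points higher from compound 2 to compound 4 (beyond the scatter). The two groups have the same number of heavy atoms and neither has a hydrogen-bond donor or acceptor, so these counts alone do not capture what separates them. No measurement here explains the step.

This one swap adds a fluorine and also rearranges the ring substituents, so the compounds shown cannot separate the contribution of either change. Going by these compounds, it also remains open whether a related group such as 3-chloro-5-methylphenyl or 3,5-difluorophenyl would give a similar number, and whether 3-fluoro-5-methylphenyl would have the same effect on the core of compound 1.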